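Replacing 3-hydroxynaphthalen-2-yl in compound 2

The source may report more compounds than this note shows. Statements on the series, on what has been measured and on what is new or still open speak of the compounds shown alone.

In a functional assay on DU-145 cells (Homo sapiens) for inhibition, read by sulforhodamine B assay, with a stated time of 48 h (on this read-out higher numbers stand for weaker inhibition of growth and lower numbers for stronger inhibition of growth), compound 2 `O=C(NNC(=O)c1cc2ccccc2cc1O)c1ccc2[nH]c(-c3ccc([N+](=O)[O-])s3)nc2c1` gives 62.5 ug/mL, the higher of two numbers and so the weaker inhibition, and compound 1 `COc1cccc(C(=O)NNC(=O)c2ccc3[nH]c(-c4ccc([N+](=O)[O-])o4)nc3c2)c1` gives 15.6 ug/mL. The gap between these two numbers lies beyond the usual scatter. Compound 3 `COc1cccc(C(=O)NNC(=O)c2ccc3[nH]c(-c4ccc([N+](=O)[O-])s4)nc3c2)c1` has 3-methoxyphenyl in place of 3-hydroxynaphthalen-2-yl on a carbonyl carbon. Compound 1 also carries 3-methoxyphenyl and gives 15.6 ug/mL, so a moderate fall in the number, meaning stronger inhibition, is expected in this assay. The estimated change is a 2.5-fold lower number from compound 2 to compound 3 (0.40 log units; beyond the scatter). For compound 3 the expected value is 25 ug/mL, with an estimated range of 10 ug/mL to 62.5 ug/mL.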

Compound 3, concentration for 50% growth inhibition: 62.5 ug/mL
Compound 3: the middle estimate sits 2.5-fold (0.40 log units) below what was measured; the range from low to high includes it.
By their numbers in this assay, from the lowest: compound 1; then compounds 2 and 3 (each within the scatter of the next).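

In this assay the swap to 3-methoxyphenyl on a carbonyl carbon gives no change at the digits printed from compound 2 to compound 3 (within the scatter) even though one of the two aromatic rings of 3-hydroxynaphthalen-2-yl is gone. The other change, 5-nitrothiophen-2-yl in place of 5-nitrofuran-2-yl on an aromatic carbon, gives a 4.0-fold higher number from compound 1 to compound 3 (0.60 log units; beyond the scatter) and so is the one that moves the number among these compounds. Nothing measured here explains either result. On these data alone, whether an amine or a carboxylic acid in place of 3-methoxyphenyl on that carbonyl carbon would shift the number stays open. Also open, as far as these compounds go, is whether 3-hydroxynaphthalen-2-yl and 3-methoxyphenyl would match when 5-nitrofuran-2-yl is present.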